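Amino for Hydroxy on the Saturated Ring Carbon

A few compounds are considered here, and "the series" means these few. Any claim that something is new, unique, unknown or untested is made for them only; others in the source may bear on it.

Three measured compounds share one core and differ only in the group on the saturated ring. Compound 1 `OC1CCN(c2ncnc3[nH]cc(-c4cccc(Cl)c4)c23)CC1` gives 127 nM in an assay for inhibition of serine/threonine-protein kinase 3 (Homo sapiens), read by luminescence and ADP-Glo, in the presence of a further agent that is not named here; on this read-out higher numbers stand for weaker inhibition and lower numbers for stronger inhibition. Compound 2 `CNC1CCN(c2ncnc3[nH]cc(-c4cccc(Cl)c4)c23)CC1` gives 293 nM in this assay, and compound 3 `CC1(O)CCN(c2ncnc3[nH]cc(-c4cccc(Cl)c4)c23)CC1` gives 189 nM in this assay. Compound 3 stands second highest of the three numbers, with both neighbours inside the scatter: a 1.5-fold higher number from compound 1 to compound 3 (0.17 log units; within the scatter) and a 1.6-fold lower number from compound 2 to compound 3 (0.19 log units; within the scatter).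

Compound 4 `CC1(N)CCN(c2ncnc3[nH]cc(-c4cccc(Cl)c4)c23)CC1` differs from compound 3 by amino in place of hydroxy on a saturated ring carbon. The step that bears on this most closely is a 2.3-fold higher number from compound 1 to compound 2 (0.36 log units; beyond the scatter), where methylamino likewise replaced hydroxy on the same saturated ring carbon; that step was modest but beyond the scatter. Among the measured compounds shown here, no measured pair separates amino from methylamino, so the exact size is uncertain. A modest rise of comparable size is therefore expected in this assay, a 1.7-fold higher number from compound 3 to compound 4 (0.23 log units; within the scatter). Compound 4 is estimated at 320 nM, with a range from 130 nM to 800 nM.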

Compound 4, half-maximal inhibitory concentration: 278 nM
Compound 4: the middle estimate sits 1.2-fold (0.06 log units) above what was measured; low and high end bracket the measured number.
By their numbers in this assay, from the lowest: compounds 1, 3, 4 and 2 (each within the scatter of the next, the first and the last beyond it).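

In this assay, the exchange of 4-hydroxy-4-methylpiperidin-1-yl for 4-amino-4-methylpiperidin-1-yl (a 1.5-fold higher number from compound 3 to compound 4 (0.17 log units; within the scatter)) cannot be told apart from no change, so with methyl on the same ring carbon, amino and hydroxy read alike. The amino and methylamino groups cannot be separated here either (a 1.1-fold lower number from compound 2 to compound 4 (0.02 log units; within the scatter)), whereas 4-amino-4-methylpiperidin-1-yl in place of 4-hydroxypiperidin-1-yl gives a modest step beyond the scatter (a 2.2-fold higher number from compound 1 to compound 4 (0.34 log units; beyond the scatter)). No measured evidence bears on why these groups read as they do.

From the compounds shown here alone, a 4-aminopiperidin-1-yl group would separate the contribution of amino from that of methyl in that last step, and this split stays open. Also open, going by these compounds, is whether a dimethylamino group, a carboxylic acid or a longer chain on this ring carbon would move the number beyond the scatter.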